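Chloro step from compound 2: cytotoxicity notes

The source may report more compounds than this note shows. Statements on the series, on what has been measured and on what is new or still open speak of the compounds shown alone.

Going by the values given here, in an ADME assay on HeLa cells (Homo sapiens) for cytotoxicity (on this read-out lower numbers stand for higher toxicity in this test and higher numbers for lower toxicity in this test), compound 2 `CCN(CC)CN1C(=O)/C(=N/NC(=S)Nc2ccc(C)cc2)c2ccccc21` gives 10700 nM, the only numeric value so far. Compound 1 `CCN(CC)CN1C(=O)/C(=N/NC(N)=S)c2cc(Cl)ccc21` reads > 100000 nM, which is a limit of the assay and not a number. Compound 3 `CCN(CC)CN1C(=O)/C(=N/NC(=S)Nc2ccc(C)cc2)c2cc(Cl)ccc21` differs from compound 2 by chloro in place of hydrogen on an aromatic carbon. Among the compounds with values here, no measured step isolates this change in this assay. The expected step is a 1.2-fold lower number from compound 2 to compound 3 (0.08 log units; within the scatter), with nothing expected beyond the scatter. For compound 3 the estimated value is 9000 nM, with an expected range of 3000 nM to 30000 nM.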

Compound 3, half-maximal cytotoxic concentration: > 100000 nM
Compound 3 ended at the assay's limit (the forecaster's own chance of this, stated with the estimate: 7%); middle value at least 11-fold (1.04 log units) away from the limit.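

Chloro in place of hydrogen on this aromatic carbon gives the first readable step in the series in this assay, and it runs towards lower toxicity in this test: an at least 9.3-fold higher number from compound 2 to compound 3 (0.97 log units; beyond the scatter). Going by these compounds, that step is only a bound, and its full size stays unknown: the limit of > 100000 nM in this assay, at which 2 of the 3 values shown sit. The step between the two compounds at the limit cannot be read.

On these data alone, whether fluoro, bromo or methoxy on the same aromatic carbon moves the number the same way remains open. So does whether the chloro step holds with a longer alkyl chain in place of 4-methylphenyl on the amide-type nitrogen.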